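The source may report more compounds than this note shows. Statements on the series, on what has been measured and on what is new or still open speak of the compounds shown alone.

Working notes on the series. Compound 1 `COc1cc(-c2nn(-c3cccc(NC(=O)c4cccc(C(F)(F)F)c4)c3)cc2-c2ccncc2)ccc1Cl` gives 4010 nM in a functional assay on OVCAR-5 cells (Homo sapiens) for inhibition, read by sulforhodamine B assay, with a stated time of 48 h; on this read-out higher numbers stand for weaker inhibition of growth and lower numbers for stronger inhibition of growth. Compound 2 `COc1cc(-c2nn(-c3cccc(NC(=O)Nc4ccc(Cl)c(Cl)c4)c3)cc2-c2ccncc2)ccc1Cl` carries (3,4-dichlorophenyl)amino on the carbonyl carbon where compound 1 carries 3-(trifluoromethyl)phenyl. In this assay compound 2 gives 2130 nM. Compound 3 `O=C(Nc1cccc(-n2cc(-c3ccncc3)c(-c3ccc(Cl)c(O)c3)n2)c1)Nc1ccc(Cl)c(Cl)c1`, with hydrogen in place of methyl on an oxygen on an aromatic ring, gives 2400 nM. The three numbers sit close together: compound 2 gives the smallest of the three, but the step of a 1.9-fold lower number from compound 1 to compound 2 (0.27 log units; within the scatter) and the step of a 1.1-fold higher number from compound 2 to compound 3 (0.05 log units; within the scatter) both lie within the scatter, so no order among them can be claimed.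

Compound 4 `COc1cc(-c2nn(-c3cccc(NC(=O)c4ccc(Cl)c(C(F)(F)F)c4)c3)cc2-c2ccncc2)ccc1Cl` has not been measured. Its difference from compound 2 is 4-chloro-3-(trifluoromethyl)phenyl in place of (3,4-dichlorophenyl)amino on a carbonyl carbon; the amide-type nitrogen and the shared core remain. Among the measured compounds shown here, the only measured step that bears on this change is the one from compound 1 to compound 2, which runs in the opposite direction and was a 1.9-fold lower number from compound 1 to compound 2 (0.27 log units; within the scatter), within the scatter. Compound 4 therefore resembles compound 1 in carrying an aryl group directly on the carbonyl carbon, with one chlorine added. The expected step is a 1.6-fold higher number from compound 2 to compound 4 (0.22 log units; within the scatter), a number somewhat higher than that of compound 2 and not beyond the scatter. Compound 4 is estimated at 3500 nM, with a range from 1500 nM to 8000 nM.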

Compound 4, concentration for 50% growth inhibition: > 32500 nM
Compound 4: only a limit was reported; the forecaster's own chance of this, stated with the estimate: 3%; at least 9.2-fold (0.96 log units) between middle value and limit.
By their numbers in this assay, from the lowest: compounds 2, 3 and 1 (each within the scatter of the next). At a limit, above all of these: compound 4.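

In this assay compound 4 stands at a limit of the assay and not at a number: the limit of > 32500 nM in this assay, at which 1 of the 4 values shown sits. Chloro in place of hydrogen on an aromatic carbon gives an at least 8.1-fold higher number from compound 1 to compound 4 (0.90 log units; beyond the scatter), so a single added chloro on the aryl group at the carbonyl carbon separates two compounds, which no earlier exchange in the series had done beyond the scatter. With 4-chloro-3-(trifluoromethyl)phenyl in place of (3,4-dichlorophenyl)amino on a carbonyl carbon the step is an at least 15-fold higher number from compound 2 to compound 4 (1.18 log units; beyond the scatter), and compound 1, which also has no amino group at this place, stays within the scatter of the other measured compounds, so removal of the amino group alone does not go with a step of this size.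

The compounds shown leave open whether the chloro acts alone or only together with the trifluoromethyl, which a 4-chlorophenyl group on the carbonyl carbon would separate, and whether (4-chloro-3-(trifluoromethyl)phenyl)amino would keep the number near those of the ureas. Also open, as far as these compounds go, is whether a methyl or a methoxy in place of that chloro would give a step of similar size.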